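A few compounds are considered here, and "the series" means these few. Any claim that something is new, unique, unknown or untested is made for them only; others in the source may bear on it.

Working notes on the series in a functional assay on CHO cells for agonist activity at Alpha-1D adrenergic receptor (Homo sapiens), read by FLIPR and calcium flux; a lower number here means that less compound is needed, a higher number that more compound is needed for the effect. Compound 1 `CS(=O)(=O)Nc1cccc2c1CCC2c1ncc[nH]1` returns only a limit, > 10000 nM, not a number. Compound 2 `Cc1oncc1-c1cccc2c1CCC2c1ncc[nH]1` likewise returns a limit, > 10000 nM. The step that the two limits leave unreadable from compound 1 to compound 2 is therefore unreadable, as both values sit at the limit of > 10000 nM in this assay, at which 2 of the 2 values shown sit. Within the data shown here, compound 2 thus stands at the limit of this assay, without a numerical position on the scale, and no measured compound of the set resolves a number.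

Compound 3 `CNC(=O)c1cccc2c1CCC2c1ncc[nH]1` differs from compound 2 by methylcarbamoyl in place of 5-methyl-1,2-oxazol-4-yl on an aromatic carbon. Among the measured compounds shown here, no measured step bears on this exchange; the single recorded step is itself unreadable, so its size gives no guidance. The step from compound 2 to compound 3 is expected to be a step that the limit leaves unreadable from compound 2 to compound 3, with no direction supported by the data. Compound 3 is estimated at 15000 nM in this assay, within 3000 nM to 100000 nM, and a further limit rather than a number is judged the likelier outcome.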

Compound 3, half-maximal effective concentration: > 10000 nM
Compound 3: no number, only a limit; the forecaster's own chance of this, stated with the estimate: 70%; the middle value lies beyond the limit too.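

In this assay the steps from compound 1 and from compound 2 to compound 3 cannot be read, as all three compounds return only a limit: the limit of > 10000 nM in this assay, at which 3 of the 3 values shown sit.

Left open is whether in this assay any group on this aromatic carbon of the shared core gives a number, and how methanesulfonamido, 5-methyl-1,2-oxazol-4-yl and methylcarbamoyl rank.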